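This account rests on a few compounds, and the source may have more. Where it says the series, first, only, none or still open, it means among the compounds named here.

Compound 1 `COc1ccc(-c2cc3c(OC)cc(OC)cc3n(C)c2=O)cc1` is the starting point. In a functional assay on PC-3 cells (Homo sapiens) for cytotoxicity, read by colorimetric assay and MTT assay (on this read-out lower numbers stand for stronger inhibition and higher numbers for weaker inhibition), compound 1 gives 10000 nM. Compound 2 `COc1ccc(-c2cc3c(OC)cc(OC)cc3n(CCCC#N)c2=O)cc1` gives 10000 nM and compound 3 `COc1ccc(-c2cc3c(OC)cc(OC)cc3n(CC(=O)OCc3ccccc3)c2=O)cc1` gives 10000 nM, so compound 1 sits level with both at the digits shown. The step to compound 4 `COc1cc(OC)c2cc(-c3ccc(O)cc3)c(=O)n(C)c2c1` is hydrogen in place of methyl on an oxygen on an aromatic ring. Among the compounds with values here, the three measured steps, no change at the digits printed from compound 1 to compound 2 (within the scatter), no change at the digits printed from compound 1 to compound 3 (within the scatter) and no change at the digits printed from compound 2 to compound 3 (within the scatter), all alter the group on the aromatic nitrogen and none touches the oxygen on the aromatic ring, so no measured step bears directly on this change. Lacking such a comparison, the step of no change at the digits printed from compound 1 to compound 4 (within the scatter) is expected to stay within the scatter. Compound 4 is therefore estimated at 10000 nM, with a range from 4000 nM to 20000 nM.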

Compound 4, half-maximal inhibitory concentration: 10000 nM
The estimate for compound 4 equals the measured number at the digits printed; low and high end bracket the measured number.
By their numbers in this assay, from the lowest: compounds 1, 2, 3 and 4 (each within the scatter of the next).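

Replacing methoxy with hydroxy at the oxygen on an aromatic ring gives no change at the digits printed from compound 1 to compound 4 (within the scatter) in this assay. Within the data shown here, this is the first reading at this position, as the earlier steps all altered the group on the aromatic nitrogen, and a free hydroxy on the 4-hydroxyphenyl group reads the same as the methoxy it replaces. Nothing at hand explains this result. The compounds shown leave open whether an amine, a carboxylic acid or a longer alkoxy chain in place of this hydroxy would shift the reading.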